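This account rests on a few compounds, and the source may have more. Where it says the series, first, only, none or still open, it means among the compounds named here.

Compound 1 `Cc1cc(=O)oc2ccc(OCNc3ccc(F)cc3)cc12`: 30700 nM
Compound 2 `Cc1cc(=O)oc2ccc(OCNc3ccccc3O)cc12`: 22900 nM

In an ADME assay on Vero cells (Chlorocebus sabaeus) for cytotoxicity (a lower number here means a stronger inhibitor, a higher number a weaker inhibitor), compound 2 stands within the usual scatter of compound 1, so these two numbers cannot be told apart. The compound now in question is compound 3 `COc1ccccc1NCOc1ccc2oc(=O)cc(C)c2c1`, which differs from compound 2 in one place: methyl in place of hydrogen on an oxygen on an aromatic ring. Put simply, a methyl takes the place of a hydrogen on an oxygen on an aromatic ring, turning hydroxy into methoxy.

Among the compounds with values here, only one measured step bears on this: a 1.3-fold lower number from compound 1 to compound 2 (0.13 log units; within the scatter). That step put 2-hydroxyphenyl in place of 4-fluorophenyl on an amine nitrogen, and it stayed within the scatter. It is weak guidance, since no measured pair tests hydroxy to methoxy directly, and it gives no reason to favour either direction. In this assay, the expected result is therefore no step beyond the scatter, and the estimate is a 1.1-fold higher number from compound 2 to compound 3 (0.04 log units; within the scatter). For compound 3 the estimated value is 25000 nM, with an expected range from 11000 nM to 55000 nM.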

Compound 3, half-maximal inhibitory concentration: 21300 nM
For compound 3 the middle estimate is 1.2-fold (0.07 log units) above the measured one; low and high end bracket the measured number.
By their numbers in this assay, from the lowest: compounds 3, 2 and 1 (each within the scatter of the next).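

Turning the hydroxy group into methoxy gives, in this assay, a 1.1-fold lower number from compound 2 to compound 3 (0.03 log units; within the scatter). Within the data shown here, this pair is the first direct test of this oxygen on the aromatic ring, and it shows that a methyl can take the place of the hydrogen there without a step that stands out from repeat measurements. Nothing available gives a reason why these two numbers lie so close together.

On these data alone, what remains open is whether a larger group on this oxygen, such as an ethyl or a longer chain, or an amine in place of the hydroxy group, would also stay within the scatter of compound 2 in this assay. A single pair also cannot say whether the same swap from hydroxy to methoxy would behave this way on a different aromatic group, such as one that also carries a carboxylic acid.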